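Placing an aryl group on the ring nitrogen of compound 2

The source may hold more compounds than are shown below. What is called first, only, known or untested is meant among the compounds shown, and "the series" means these compounds.

Compound 2 `O=C1NC(=O)C2(CSC3=C2C(=O)c2ncccc2C3=O)N1` is the most potent of the three compounds measured in a functional assay on HeLa cells (Homo sapiens) for antiproliferative activity, read by MTT assay, with a stated time of 96 h; on this read-out higher numbers stand for weaker inhibition and lower numbers for stronger inhibition: compound 2 gives 150 nM. Compound 3 `O=C1NN(c2ccc([N+](=O)[O-])cc2)C(=O)C2(CSC3=C2C(=O)c2ncccc2C3=O)N1` gives 610 nM, and compound 1 `O=C1NNC(=O)C2(CSC3=C2C(=O)c2ncccc2C3=O)N1` gives 980 nM; both steps from compound 2 lie beyond the scatter, so compound 2 stands clearly at the lowest number. The unmeasured compound 4 `CC(C)(C)c1ccc(N2C(=O)NC3(CSC4=C3C(=O)c3ncccc3C4=O)C2=O)cc1` differs from compound 2 in one place: 4-(tert-butyl)phenyl in place of hydrogen on an amide-type nitrogen in a ring. One measured step resembles this change in kind: a 1.6-fold lower number from compound 1 to compound 3 (0.21 log units; within the scatter). That step also placed an aryl group on an amide-type nitrogen in a ring and moved the number by no more than the scatter, although the cores of compound 1 and compound 2 are not the same, so the parallel is imperfect, and the substituent on the aryl ring differs as well. Among the measured compounds shown here, on this basis the step of a 1.3-fold higher number from compound 2 to compound 4 (0.12 log units; within the scatter) is expected to stay within the scatter, because the one comparable step a 1.6-fold lower number from compound 1 to compound 3 (0.21 log units; within the scatter) was itself within it. Compound 4 is therefore estimated at 200 nM, with a range from 90 nM to 450 nM.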

Compound 4, half-maximal inhibitory concentration: 100 nM
Estimate against measurement, compound 4: 2.0-fold (0.30 log units) above; the range from low to high includes it.
By their numbers in this assay, from the lowest: compounds 4 and 2 (each within the scatter of the next); then compounds 3 and 1 (each within the scatter of the next).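

On the core of compound 2 itself, the amide-type nitrogen in a ring now carries 4-(tert-butyl)phenyl, a group of 10 heavy atoms, in place of hydrogen, and in this assay the result is a 1.5-fold lower number from compound 2 to compound 4 (0.18 log units; within the scatter). Before this, the only aryl group at such a nitrogen was the 4-nitrophenyl of compound 3, on the different core of compound 1, so the new step is the first direct reading of this change on the core of compound 2, and it shows that this large aryl group leaves the number within the scatter of the hydrogen compound. With a 1.6-fold lower number from compound 1 to compound 3 (0.21 log units; within the scatter), there are now two such aryl steps on two cores, both within the scatter, though they differ in both core and aryl group, and no measured property of either group is available to account for this result.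

The compounds shown leave open whether the same would hold for a longer alkyl chain at this nitrogen, or for a phenyl ring bearing an amine or a carboxylic acid. They also leave open whether 4-nitrophenyl would behave on the core of compound 2 as 4-(tert-butyl)phenyl does.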